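The source may hold more compounds than are shown below. What is called first, only, known or untested is meant among the compounds shown, and "the series" means these compounds.

In a functional assay on C6 cells (Rattus norvegicus) for cytotoxicity, read by MTT assay, with a stated time of 24 h, tested at 12 ug/mL (on this read-out higher numbers stand for a weaker effect at the one concentration tested and lower numbers for a stronger effect), three compounds of a shared core have been measured. Compound 1 `Cc1nnc(SCC(=O)N/N=c2/scc(-c3ccccc3)n2-c2ccccc2)s1` gives 72.5%, compound 2 `Cn1nnnc1SCC(=O)N/N=c1/scc(-c2ccc([N+](=O)[O-])cc2)n1-c1ccccc1` gives 76.2%, and compound 3 `Cc1ccc(-c2cs/c(=N/NC(=O)CSc3ncccn3)n2-c2ccccc2)cc1` gives 83%. On these numbers compound 2 sits nearest compound 1 and furthest from compound 3, yet both gaps lie within the usual scatter, so the three readings cannot be told apart. The next compound, compound 4 `Cn1nnnc1SCC(=O)N/N=c1/scc(-c2ccccc2)n1-c1ccccc1`, differs from compound 2 in one place: hydrogen in place of nitro on an aromatic carbon. Within the data shown here, no measured pair shows this change on its own, so the data give no ground for a shift in this assay, and the step from compound 2 to compound 4 is expected to stay within the scatter, at a number 1.2 percentage points lower from compound 2 to compound 4 (within the scatter). Compound 4 is therefore estimated at 75%, expected between 63% and 87%.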

Compound 4, a percentage reported as activity, at one concentration (the size of the read-out at that concentration, not a potency): 80.7%
For compound 4 the middle estimate is 5.7 percentage points below the measured one, within the range that was stated.
By their numbers in this assay, from the lowest: compounds 1, 2, 4 and 3 (each within the scatter of the next, the first and the last beyond it).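

In this assay the first pair differing in one place shows hydrogen in place of nitro on an aromatic carbon, para to a large group, as a number 4.5 percentage points higher from compound 2 to compound 4 (within the scatter) and so no shift that can be told from the scatter at this position. Likewise, 1-methyl-1H-tetrazol-5-yl in place of 5-methyl-1,3,4-thiadiazol-2-yl on the sulfur reads as a number 8.2 percentage points higher from compound 1 to compound 4 (within the scatter) and cannot be told from the scatter either. No measurement shown explains either step.

As far as these compounds go, whether an amine or a carboxylic acid at this aromatic carbon, or a longer chain on the sulfur, would move the number beyond the scatter stays open. So does whether the nitro-to-hydrogen step would read the same with another group on the sulfur.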